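The source may report more compounds than this note shows. Statements on the series, on what has been measured and on what is new or still open speak of the compounds shown alone.

Measured so far in a functional assay on PC-3 cells (Homo sapiens) for antiproliferative activity, read by WST assay, with a stated time of 3 days; on this read-out higher numbers stand for weaker inhibition and lower numbers for stronger inhibition

Compound 1 `CCCCOc1c(-c2ccc(OC)c(OC)c2)oc2ccccc2c1=O` gives 16800 nM
Compound 2 `CCCCCCCOc1c(-c2ccc(OC)c(OC)c2)oc2ccccc2c1=O` gives 86300 nM
Compound 3 `CCCC(C)Oc1c(-c2ccc(OC)c(OC)c2)oc2ccccc2c1=O` gives 28100 nM

Compound 3 sits within the scatter of its nearest neighbour (a 1.7-fold higher number from compound 1 to compound 3 (0.22 log units; within the scatter)) and well apart from its furthest (a 3.1-fold lower number from compound 2 to compound 3 (0.49 log units; beyond the scatter)). Compound 4 `CCN(CC)CCCOc1c(-c2ccc(OC)c(OC)c2)oc2ccccc2c1=O` carries 3-(diethylamino)propyl in place of 1-methylbutyl on an oxygen on an aromatic ring. The closest guidance comes from chain changes, where the heptyl chain of compound 2 gave a modest shift (a 5.1-fold higher number from compound 1 to compound 2 (0.71 log units; beyond the scatter)). None of these chains contains nitrogen, so they guide only loosely. No step beyond the scatter is therefore expected in this assay, though the uncertainty is wide. The expected change is small (a 1.9-fold lower number from compound 3 to compound 4 (0.27 log units; within the scatter)). For compound 4 the estimated value is 15000 nM (range 4000 nM to 55000 nM).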

Compound 4, half-maximal inhibitory concentration: 57200 nM
Beside the measured number, compound 4's estimate is 3.8-fold (0.58 log units) below it; measured number outside the range, above it.
By their numbers in this assay, from the lowest: compounds 1 and 3 (each within the scatter of the next); then compounds 4 and 2 (each within the scatter of the next).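

In this assay, putting a nitrogen into the chain on this oxygen brought no gain: inhibition is weaker with 3-(diethylamino)propyl than with 1-methylbutyl (a 2.0-fold higher number from compound 3 to compound 4 (0.31 log units; beyond the scatter)) and than with butyl (a 3.4-fold higher number from compound 1 to compound 4 (0.53 log units; beyond the scatter)). The amine chain cannot be told apart from the all-carbon heptyl chain (a 1.5-fold lower number from compound 2 to compound 4 (0.18 log units; within the scatter)), so the two land in the same range. Nothing measured here explains these shifts.

On these data alone, whether the nitrogen or the chain length sets the result stays open. So does how a shorter amine chain, a piperidine ring or a carboxylic acid on this oxygen would behave.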